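This account rests on a few compounds, and the source may have more. Where it says the series, first, only, none or still open, it means among the compounds named here.

Compound 3 `C/C(=N/O)c1ccc(OCC(=O)Nc2ccc(C(=O)/C=C/c3ccc(Cl)cc3)cc2)cc1` gives 39% in a functional assay on the whole organism (strain albino) for inhibition, with Rattus norvegicus as the target, read by paw edema, with stated times of 30 min and 1 h, at a dose of 100 mg/kg by the oral route (on this read-out lower numbers stand for less inhibition and higher numbers for more inhibition at the one dose given (going by the name of the read-out)), a number within the scatter of compound 1 `COc1ccc(/C=C/C(=O)c2ccc(NC(=O)CBr)cc2)cc1` with 37% and of compound 2 `COc1ccc(/C=C/C(=O)c2ccc(NC(=O)CO[N+](=O)[O-])cc2)cc1` with 33%. Compound 4 `COc1ccc(/C=C/C(=O)c2ccc(NC(=O)COc3ccc(/C(C)=N\O)cc3)cc2)cc1` differs from compound 3 by methoxy in place of chloro on an aromatic carbon. Within the data shown here, the only measured step, a number 4 percentage points lower from compound 1 to compound 2 (within the scatter), concerns nitrooxy in place of bromo on a saturated chain carbon bound to a carbonyl carbon and does not bear on a change at an aromatic carbon. Among the measured compounds shown here, compounds 1 and 2 carry the methoxy that enters, but they differ from compound 3 in another place as well, so no step isolates this change. Compound 4 is therefore expected to show a number 1 percentage points lower from compound 3 to compound 4 (within the scatter), none beyond the scatter. The estimate for compound 4 is 38%, between 28% and 48%.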

Compound 4, a percentage reported as inhibition, in the whole organism at one dose (the size of the read-out at that dose, not a potency): 33%
Compound 4: middle estimate off by 5 percentage points, on the high side; the range from low to high includes it.
By their numbers in this assay, from the lowest: compounds 2, 4, 1 and 3 (each within the scatter of the next).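

In this assay, among these compounds, this is the first step that isolates the para position of this aromatic ring, and 4-methoxyphenyl in place of 4-chlorophenyl leaves the number within the scatter (a number 6 percentage points lower from compound 3 to compound 4 (within the scatter)). The larger replacements on the chain also stay within the scatter (no change at the digits printed from compound 2 to compound 4 (within the scatter)) (a number 4 percentage points lower from compound 1 to compound 4 (within the scatter)). Nothing measured here offers an explanation for these numbers. From the compounds shown here alone, whether an amine or a carboxylic acid at this aromatic carbon would move the number remains open. So does whether this change would read the same with the bromo or nitrooxy chain.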